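This account rests on a few compounds, and the source may have more. Where it says the series, first, only, none or still open, it means among the compounds named here.

Compound 1 `COc1cc(-c2nccn2C(C)C)cc(OC)c1OC` carries an isopropyl group on the ring nitrogen of its core. In a functional assay on MDA-MB-231 cells (Homo sapiens) for antiproliferative activity, read by MTT assay, with a stated time of 72 h (a lower number here means a stronger inhibitor, a higher number a weaker inhibitor), compound 1 gives > 100000 nM, which is a limit of the assay rather than a number, so compound 1 stands at the limit of > 100000 nM in this assay, at which 1 of the 3 values shown sits. The two other measured compounds carry an aromatic group on that same nitrogen. Compound 2 `COc1cc(-c2nccn2-c2ccc3[nH]ccc3c2)cc(OC)c1OC` gives 4300 nM in this assay, and compound 3 `COc1cc(OC)cc(-n2ccnc2-c2cc(OC)c(OC)c(OC)c2)c1` gives 45200 nM in this assay. Compound 4 `COc1cc(-c2nccn2-c2ccc(Br)cc2)cc(OC)c1OC` differs from compound 1 by 4-bromophenyl in place of isopropyl on an aromatic nitrogen. For compound 4 the step of an at least 6.6-fold lower number from compound 1 to compound 4 (0.82 log units; beyond the scatter) is expected to lie well beyond the scatter, toward stronger inhibition. Compound 2 gives 4300 nM and compound 3 gives 45200 nM, and both carry an aromatic group on the ring nitrogen, as compound 4 does. Compound 4 is estimated at 15000 nM, with a range from 3000 nM to 70000 nM, a position between the two aryl-bearing compounds already measured.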

Compound 4, half-maximal inhibitory concentration: 8400 nM
Compound 4: the middle estimate sits 1.8-fold (0.25 log units) above what was measured; the measured number falls inside the stated range.
By their numbers in this assay, from the lowest: compounds 2 and 4 (each within the scatter of the next); then compound 3. At a limit, above all of these: compound 1.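

In this assay, putting 4-bromophenyl in place of isopropyl on the aromatic nitrogen gives an at least 11-fold lower number from compound 1 to compound 4 (1.07 log units; beyond the scatter), so this one change, with the rest of the core kept, brings the number into the measurable range. Compound 1 stands at a limit of the assay, so the step gives only a minimum size: the limit of > 100000 nM in this assay, at which 1 of the 4 values shown sits. Compound 4 and compound 2 lie within the scatter of each other, which shows that two different aromatic groups on this nitrogen can read alike.

The compounds shown leave open whether the step comes from the aromatic ring or from the bromine, which a plain phenyl group on this nitrogen would help to separate. Also open, as far as these compounds go, is what a longer alkyl chain, a 4-aminophenyl group or a 4-carboxyphenyl group would give here.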